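The compounds below may be only part of what the source reports. "The series", "measured", "known", "first", "only" and "open" are said of these compounds alone.

Measured compounds:
Compound 1, `Cc1cc(-c2ccc(Cl)cc2)c(/C=C/[C@@H]2C[C@@H](O)CC(=O)O2)c(C)n1`, in an assay for inhibition of 3-hydroxy-3-methylglutaryl-coenzyme A reductase (Rattus norvegicus) (a higher number here means a weaker inhibitor, a lower number a stronger inhibitor), compound 1 gives 94 nM.
Compound 2, `CCc1nc(-c2ccccc2)cc(-c2ccc(F)cc2)c1/C=C/[C@@H]1C[C@@H](O)CC(=O)O1`, in this assay compound 2 gives 40 nM.
Compound 3, `Cc1cc(-c2ccc(F)cc2)c(/C=C/[C@@H]2C[C@@H](O)CC(=O)O2)c(C(C)C)n1`, in this assay compound 3 gives 9 nM.

All three share the same lactone-bearing side chain on a six-membered aromatic ring with one nitrogen, and differ in the groups around that ring. Compound 3 has the lowest number of the three in this assay; its steps to compound 2 and to compound 1 both lie beyond the usual scatter, so compound 3 is the strongest inhibitor among them.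

Compound 4, `CC(C)c1nc(C(C)(C)C)cc(-c2ccc(F)cc2)c1/C=C/[C@@H]1C[C@@H](O)CC(=O)O1`, has not yet been measured. It differs from compound 3 in one place: tert-butyl in place of methyl on an aromatic carbon. The group next to the ring nitrogen thus grows from one carbon to four carbons, while the 4-fluorophenyl group, the isopropyl group and the side chain stay as in compound 3. Going by the values given here, no pair among the measured compounds shows this change alone, so there is no measured step to lean on. The expectation is that the step from compound 3 to compound 4 in this assay will be small, a 1.1-fold higher number from compound 3 to compound 4 (0.05 log units; within the scatter), without a clear direction beyond the scatter. Compound 4 is therefore estimated at 10 nM, within a range of 3 nM to 35 nM.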

Compound 4, half-maximal inhibitory concentration: 1 nM
For compound 4 the middle estimate is 10-fold (1.00 log units) above the measured one; the measured number lies below the stated range.
By their numbers in this assay, from the lowest: compound 4; then compound 3; then compound 2; then compound 1.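

In this assay, the group next to the ring nitrogen can be changed with a clear effect on the number: tert-butyl in place of methyl gives a 9.0-fold lower number from compound 3 to compound 4 (0.95 log units; beyond the scatter). The earlier compounds shown here could not show this, as no two of them differed in one place only; here the 4-fluorophenyl group, the isopropyl group and the side chain stay the same, so the step belongs to this single change on the shared core. Nothing measured here explains why the number falls with this change.

Going by these compounds alone, a single step joins only two groups at this position, so it cannot show whether the number would fall gradually across groups with between one and four carbons or whether tert-butyl is a special case. It also leaves open how quite different groups would behave in the same place, such as a cyclopropyl ring, an amine or a carboxylic acid, and whether the same change would give a similar step with the 4-chlorophenyl group of compound 1 on the core.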